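Replacing an amide with a hydroxyl at the piperidine chain end

A few compounds are considered here, and "the series" means these few. Any claim that something is new, unique, unknown or untested is made for them only; others in the source may bear on it.

Measured compounds:
Compound 1, `O=S1(=O)Cc2nc(-c3cc(F)c(Cl)cc3F)nc(N3CCC(CO)CC3)c2C1`, gives 3.9 nM in a functional assay on HEK293 cells for agonist activity at Glucose-dependent insulinotropic receptor (Homo sapiens), read by reporter gene assay and cAMP accumulation, with a stated time of 6 h; on this read-out higher numbers stand for an effect only at larger amounts of compound and lower numbers for an effect already at smaller amounts.
Compound 2, `O=C(O)C1CCN(c2nc(-c3cc(F)c(Cl)cc3F)nc3c2CS(=O)(=O)C3)CC1`, gives 560 nM in this assay.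
Compound 3, `NC(=O)CCC1CCN(c2nc(-c3cc(F)c(Cl)cc3F)nc3c2CS(=O)(=O)C3)CC1`, gives 18 nM in this assay.

Among these three, compound 3 stands second highest: its number lies above that of compound 1 by a 4.6-fold higher number from compound 1 to compound 3 (0.66 log units; beyond the scatter), and below that of compound 2 by a 31-fold lower number from compound 2 to compound 3 (1.49 log units; beyond the scatter). The step to the unmeasured compound 4, `O=S1(=O)Cc2nc(-c3cc(F)c(Cl)cc3F)nc(N3CCC(CCO)CC3)c2C1`, is hydroxy in place of carbamoyl on a saturated chain carbon, two bonds along the chain from a saturated ring carbon.

Within the data shown here, two measured steps bear on this. The step from compound 1 to compound 3 shows that exchanging hydroxy for carbamoylmethyl on the saturated chain carbon raised the number by a 4.6-fold higher number from compound 1 to compound 3 (0.66 log units; beyond the scatter), a modest change; the step from compound 2 to compound 3 shows that the carbamoyl-bearing chain gave a far lower number than carboxy, a 31-fold lower number from compound 2 to compound 3 (1.49 log units; beyond the scatter). Compound 4 carries a hydroxy group, as compound 1 does, only on a chain one carbon longer. The number for compound 4 is therefore expected to fall from that of compound 3, roughly by a 3.0-fold lower number from compound 3 to compound 4 (0.48 log units; beyond the scatter), back toward compound 1. The estimated value for compound 4 in this assay is 6 nM, with a likely range from 2 nM to 20 nM.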

Compound 4, effective concentration (reported as EC, without a stated level of effect): 2.8 nM
Compound 4: the middle estimate sits 2.1-fold (0.33 log units) above what was measured; low and high end bracket the measured number.
By their numbers in this assay, from the lowest: compounds 4 and 1 (each within the scatter of the next); then compound 3; then compound 2.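

In this assay hydroxy in place of carbamoyl on the saturated chain carbon gives a 6.4-fold lower number from compound 3 to compound 4 (0.81 log units; beyond the scatter) and so the carbamoyl end is not needed for a low number on this chain; a hydroxy end does better here. Setting the two hydroxy-ended chains side by side gives a 1.4-fold lower number from compound 1 to compound 4 (0.14 log units; within the scatter) so hydroxymethyl and 2-hydroxyethyl on the ring carbon cannot be told apart, and the hydroxy end holds its low number on both. Against carboxy on that same ring carbon the gap is wide, at a 200-fold lower number from compound 2 to compound 4 (2.30 log units; beyond the scatter) but this step changes the chain and the end group together, so it cannot show which of the two matters more.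

Still open, going by these compounds, is how a chain ending in an amine would read, how a chain longer than 2-hydroxyethyl would read, and whether a carboxylic acid at the end of a chain, rather than directly on the ring carbon, would give a number as high as that of compound 2. Nothing measured here explains why these end groups read as they do.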